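The source may hold more compounds than are shown below. What is called first, only, known or untested is meant among the compounds shown, and "the series" means these compounds.

Measured compounds:
compound 1, `CCn1c(SCC(=O)Nc2ccc(/C(C)=N/O)cc2)nnc1-c1ccc(OC)c(OC)c1`, 66% in a functional assay on the whole organism (strain albino) for inhibition, with Rattus norvegicus as the target, read by paw edema, with stated times of 30 min and 3 h, at a dose of 0.28 mmol/kg by the oral route; on this read-out lower numbers stand for less inhibition and higher numbers for more inhibition at the one dose given (going by the name of the read-out)
compound 2, `COc1ccc(-c2nnc(SCC(=O)Nc3ccc(/C(C)=N/O)cc3)n2-c2ccccc2)cc1OC`, 77% in this assay
compound 3, `CCn1c(SCC(=O)Nc2ccc(C(C)=O)cc2)nnc1-c1ccccc1`, 56% in this assay

Compound 3 stands lowest of the three numbers, but its gap to compound 1 is within the scatter, so no order between those two is claimed; its gap to compound 2 is beyond the scatter.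

Within the data shown here, the one counted step among the measured compounds is phenyl in place of ethyl on an aromatic nitrogen, which gave a number 11 percentage points higher from compound 1 to compound 2 (beyond the scatter). The same kind of change carries compound 3 to compound 4, `CC(=O)c1ccc(NC(=O)CSc2nnc(-c3ccccc3)n2-c2ccccc2)cc1`, as phenyl in place of ethyl on an aromatic nitrogen. The surroundings differ: in the step from compound 1 to compound 2 the ring nitrogen is next to the ring atom that bears a 3,4-dimethoxyphenyl group, whereas in the step from compound 3 to compound 4 it is next to the ring atom that bears a phenyl group. How the core of compound 3 differs from the core of compound 1 is not broken down here.

With a single earlier instance of this kind of change, the expectation for compound 4 rests on that one step. Compound 4 is expected to move by about a number 10 percentage points higher from compound 3 to compound 4 (within the scatter), in line with the earlier step, with the starting point given by compound 3 at 56% in this assay. The estimate for compound 4 is 66%, expected to lie between 54% and 78%, with the wider range reflecting that the change is only the same kind and not the same.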

Compound 4, a percentage reported as inhibition, in the whole organism at one dose (the size of the read-out at that dose, not a potency): 62%
For compound 4 the middle estimate is 4 percentage points above the measured one; measured number inside the range.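

In this assay, phenyl in place of ethyl on an aromatic nitrogen gives a number 6 percentage points higher from compound 3 to compound 4 (within the scatter), so on this core the change alone cannot be told apart from repeat measurement. Set beside the earlier step, the new step shows no difference in the size of the change between the two cores: the same change on two cores in this assay, a number 11 percentage points higher (beyond the scatter) from compound 1 to compound 2 and a number 6 percentage points higher (within the scatter) from compound 3 to compound 4, 5 percentage points apart, within the scatter of two such steps This agrees with the change carrying over from one core to the other, but with only two pairs it does not establish a transferable gain, and the step on the core of compound 3 is not itself a demonstrated gain, nor does a percentage at one dose say anything about potency.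

The compounds shown carry only ethyl and phenyl on that ring nitrogen, so the outcome with a longer chain such as butyl, or with a benzyl group, stays open. Also open is whether the step would hold on a core bearing an amine or a carboxylic acid, since the two cores shown are the only settings in which the change can be read.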